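Dropping the methoxy from compound 1: expected read-out

This account rests on a few compounds, and the source may have more. Where it says the series, first, only, none or still open, it means among the compounds named here.

Compound 1 `COc1ccc(-c2nc(C)c(C(=O)CSc3nc(N)c(C#N)c(-c4ccc(OC)cc4)n3)s2)cc1` is one of three analogues of the shared core measured in an assay on membranes from CHO cells for displacement of a labelled ligand from adenosine receptor A1 (Homo sapiens), read by scintillation counting, with a stated time of 60 min, tested at 1 uM; on this read-out lower numbers stand for less inhibition and higher numbers for more inhibition at the one concentration tested (going by the name of the read-out). In this assay compound 1 gives 9%. On the numbers shown, compound 1 stands between compound 2 `COc1ccc(-c2nc(SCC(=O)c3sc(-c4ccccc4)nc3C)[nH]c(=O)c2C#N)cc1OC`, which gives 10%, and compound 3 `COc1ccc(-c2nc(SCC(=O)c3sc(-c4ccc(Cl)cc4)nc3C)nc(N)c2C#N)cc1`, which gives 1.2%; both gaps are within the scatter, and all three numbers are small.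

Compound 4 `COc1ccc(-c2nc(C)c(C(=O)CSc3nc(N)c(C#N)c(-c4ccccc4)n3)s2)cc1` differs from compound 1 by hydrogen in place of methoxy on an aromatic carbon. Among the measured compounds shown here, the one measured step, a number 7.8 percentage points lower from compound 1 to compound 3 (within the scatter), also changes the group on an aromatic carbon of compound 1 and is within the scatter. For the measured compounds named here, no other measured pair bears on this change. Going by the values given here, with every measured compound close to the bottom of the read-out and the one related step within the scatter, no step beyond the scatter is expected, a number 2 percentage points lower from compound 1 to compound 4 (within the scatter). Compound 4 is therefore estimated to give 7% in this assay, with a range from 0% to 18%.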

Compound 4, a percentage reported as inhibition, at one concentration (the size of the read-out at that concentration, not a potency): -2.8%
The estimate for compound 4 lay 9.8 percentage points above the measured number; measured number outside the range, below it.
By their numbers in this assay, from the lowest: compounds 4, 3, 1 and 2 (each within the scatter of the next, the first and the last beyond it).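

In this assay, among the compounds shown here, 4-methoxyphenyl to phenyl gives a number 11.8 percentage points lower from compound 1 to compound 4 (beyond the scatter), the one step so far that lies beyond the scatter. For the compounds shown here, the methoxy that leaves here is not the one replaced in the step of a number 7.8 percentage points lower from compound 1 to compound 3 (within the scatter), so the two methoxy groups of compound 1 need not be treated as interchangeable, although this step is modest and compound 1 gives only 9% at the one concentration tested. No measurement at hand accounts for the step.

On these data alone, whether a hydroxy, an ethoxy, a fluoro or an amine at this place para to a large group would keep the read-out of compound 1 stays open. Also open, as far as these compounds go, is whether hydrogen in place of the other methoxy would give a step of similar size.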